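The compounds below may be only part of what the source reports. "The series", "measured", "known", "first", "only" and "open" are said of these compounds alone.

Three compounds share a core that carries a bicyclic amine and an aryl amine, and all three were tested in an assay on cell membranes for displacement of a labelled ligand from Neuronal acetylcholine receptor; alpha4/beta2 (Rattus norvegicus); on this read-out higher numbers stand for weaker inhibition and lower numbers for stronger inhibition. Compound 1 `Oc1ccc(Nc2cncc(N3CC4CC(C3)N4)c2)cc1` gives 0.342 nM in this assay. Compound 2 `c1ccc(Nc2ccc(N3CC4CC(C3)N4)cn2)cc1` gives 2.66 nM, the highest of the three numbers. Compound 3 `Clc1cccc(Nc2ccc(N3CC4CC(C3)N4)cn2)c1` gives 2.2 nM. Going by the values given here, the one step that can be isolated, a 1.2-fold lower number from compound 2 to compound 3 (0.08 log units; within the scatter), is a change on the outer benzene ring, and it left the number essentially where it was. Compound 1 differs from compound 2 in more than one place, so its lower number cannot be traced to a single change.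

Compound 4 `COc1ccc(Nc2ccc(N3CC4CC(C3)N4)cn2)cc1` is not yet measured. It differs from compound 2 in one place: methoxy in place of hydrogen on an aromatic carbon, on an aromatic carbon, para to a large group. Among the compounds with values here, the only related step, from compound 2 to compound 3, was within the scatter, so a small change on this ring gave no movement. On that basis compound 4 is expected to sit close to compound 2, perhaps a little lower, estimated at 1.8 nM with a range of 0.6 nM to 5.5 nM. The expected step is a 1.5-fold lower number from compound 2 to compound 4 (0.17 log units; within the scatter).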

Compound 4, inhibition constant: 7.3 nM
The estimate for compound 4 lay 4.1-fold (0.61 log units) below the measured number; the whole stated range lies below it.
By their numbers in this assay, from the lowest: compound 1; then compounds 3 and 2 (each within the scatter of the next); then compound 4.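

The outer benzene ring is not indifferent to substitution: in this assay, methoxy para to a large group gives a 2.7-fold higher number from compound 2 to compound 4 (0.44 log units; beyond the scatter), a modest loss of binding that lies beyond the usual scatter. The chloro change, by contrast, gave only a 1.2-fold lower number from compound 2 to compound 3 (0.08 log units; within the scatter), which lies within the scatter, so a substituent on this ring can leave the number unchanged or raise it. Nothing shown here explains why methoxy raises the number.

These compounds cannot separate the effect of the methoxy group itself from the effect of its place on the ring. Going by these compounds, it also remains open what a fluoro group, an amine or a longer chain such as ethoxy would do at this same position on the core of compound 2.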